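Notes on compound 4, the benzyl analogue of the series

The source may report more compounds than this note shows. Statements on the series, on what has been measured and on what is new or still open speak of the compounds shown alone.

Compound 3 `CCCCCCCCCC[n+]1cccc(OP(=O)([O-])OC[C@H]2O[C@@H](n3cc(F)c(=O)[nH]c3=O)C[C@@H]2OC(=O)c2ccccc2)c1` gives 8730 nM in a functional assay on T47D cells (Homo sapiens) for cytotoxicity, read by MTT assay, with a stated time of 48 h (on this read-out lower numbers stand for stronger inhibition and higher numbers for weaker inhibition), the second highest of the three numbers, close to compound 1 `O=C(O[C@H]1C[C@H](n2cc(F)c(=O)[nH]c2=O)O[C@@H]1COP(=O)(O)Oc1cccnc1)c1ccccc1` at 14400 nM and further from compound 2 `C[n+]1cccc(OP(=O)([O-])OC[C@H]2O[C@@H](n3cc(F)c(=O)[nH]c3=O)C[C@@H]2OC(=O)c2ccccc2)c1` at 3910 nM. Compound 4 `O=C(O[C@H]1C[C@H](n2cc(F)c(=O)[nH]c2=O)O[C@@H]1COP(=O)([O-])Oc1ccc[n+](Cc2ccccc2)c1)c1ccccc1` differs from compound 3 by phenyl in place of nonyl on a saturated chain carbon bound to an aromatic nitrogen. Going by the values given here, two measured steps bear on it: a 3.7-fold lower number from compound 1 to compound 2 (0.57 log units; beyond the scatter), and a 2.2-fold higher number from compound 2 to compound 3 (0.35 log units; beyond the scatter). Only the second concerns the same saturated chain carbon, and there the longer chain went with the higher number; compound 4 keeps a shorter group on that carbon, benzyl in place of decyl. A step of a 1.6-fold lower number from compound 3 to compound 4 (0.20 log units; within the scatter) is therefore expected, modest and downward, leaving compound 4 between compound 2 and compound 3. Compound 4 is estimated at 5500 nM, between 2500 nM and 12000 nM.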

Compound 4, half-maximal inhibitory concentration: 3430 nM
Compound 4: the middle estimate sits 1.6-fold (0.21 log units) above what was measured; the range from low to high includes it.
By their numbers in this assay, from the lowest: compounds 4 and 2 (each within the scatter of the next); then compounds 3 and 1 (each within the scatter of the next).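

Phenyl in place of nonyl on a saturated chain carbon bound to an aromatic nitrogen gives a 2.5-fold lower number from compound 3 to compound 4 (0.41 log units; beyond the scatter) in this assay, so the number at this place does not depend on the presence of a substituent alone. Phenyl in place of hydrogen on that carbon gives a 1.1-fold lower number from compound 2 to compound 4 (0.06 log units; within the scatter), so of the three groups compared here, only the decyl of compound 3 stands apart. Nothing available explains this difference.

The compounds shown leave open how a hexyl chain would read at this place, and whether a benzyl carrying an amine or a carboxylic acid on its ring would keep the number of compound 4.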